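Chloro in Place of Hydrogen, Tested Against a Cytotoxicity Limit

The compounds below may be only part of what the source reports. "The series", "measured", "known", "first", "only" and "open" are said of these compounds alone.

Compound 1 `CCC1(Cc2ccccc2)OS(=O)(=O)C=C1OCc1ccccc1` was examined in an ADME assay on HEL cells (Homo sapiens) for cytotoxicity, with a stated time of 3 days; a lower number here means that less compound is tolerated, a higher number that more compound is tolerated. In this assay compound 1 gives only a limit, >= 50000 nM. Compound 2 `CCC1(Cc2ccccc2)OS(=O)(=O)C=C1OCc1ccc(C)cc1` likewise gives only a limit in this assay, >= 16000 nM. The step that the two limits leave unreadable from compound 1 to compound 2 cannot be sized because both values are limits the limit of >= 16000 nM in this assay, at which 1 of the 2 values shown sits (the limit of >= 50000 nM in this assay, at which 1 of the 2 values shown sits). Compound 3 `CCC1(Cc2ccccc2)OS(=O)(=O)C=C1OCc1ccccc1Cl` differs from compound 1 by chloro in place of hydrogen on an aromatic carbon. For the measured compounds named here, no measured step bears directly on this change, and the one step measured is unreadable, so no step beyond the scatter is foreseen. Compound 3 is therefore expected to give about 50000 nM, between 16000 nM and 100000 nM, an expected step of a number no higher from compound 1 to compound 3 (the limit leaves the size open).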

Compound 3, minimum cytotoxic concentration: >= 20000 nM
Compound 3 ended at the assay's limit; the forecaster's own chance of this, stated with the estimate: 80%; the middle value is on the limit's open side.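

In this assay, for the compounds shown here, compound 1, compound 2 and compound 3 each give only a limit, and no step among them can be read. The compounds shown leave open whether chloro in place of hydrogen on an aromatic carbon shifts the minimum cytotoxic concentration at all.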